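Nitro for fluoro on the aryloxymethyl ketone end

A few compounds are considered here, and "the series" means these few. Any claim that something is new, unique, unknown or untested is made for them only; others in the source may bear on it.

The measured compounds and their numbers in a functional assay with Homo sapiens as the target; a higher number here means a weaker inhibitor, a lower number a stronger inhibitor:
compound 1, `CC(C)[C@H](NC(=O)COc1cccc2ccccc12)C(=O)N[C@@H](CC(=O)O)C(=O)COc1cccc2ccccc12`, 19000 nM
compound 2, `CC(C)[C@H](NC(=O)COc1cccc2ccccc12)C(=O)N[C@@H](CC(=O)O)C(=O)COc1ccccc1C(F)(F)F`, 17300 nM
compound 3, `CC(C)[C@H](NC(=O)COc1cccc2ccccc12)C(=O)N[C@@H](CC(=O)O)C(=O)COc1ccc(F)cc1F`, 17600 nM

Compound 3 sits in the middle of these three numbers, but the whole set is close together: the steps of a 1.1-fold lower number from compound 1 to compound 2 (0.04 log units; within the scatter), a 1.1-fold lower number from compound 1 to compound 3 (0.03 log units; within the scatter) and a 1.0-fold higher number from compound 2 to compound 3 (0.01 log units; within the scatter) all stay within the scatter. Swapping the naphthalen-1-yl group on the oxygen on a saturated carbon for 2-(trifluoromethyl)phenyl or for 2,4-difluorophenyl has changed nothing that can be resolved in this assay .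

Compound 4, `CC(C)[C@H](NC(=O)COc1cccc2ccccc12)C(=O)N[C@@H](CC(=O)O)C(=O)COc1ccc([N+](=O)[O-])cc1F`, takes the step (nitro in place of fluoro on an aromatic carbon). The change again lies on that same aryl group on the oxygen on a saturated carbon, and the three steps already seen at that part of the molecule, though none of them swaps exactly this pair of groups, were all flat. On that basis compound 4 is expected to stay where compound 3 is, with a step of a 1.0-fold lower number from compound 3 to compound 4 (0.00 log units; within the scatter) lying within the scatter. The estimate for compound 4 in this assay is 17500 nM, in a range from 8500 nM to 36000 nM.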

Compound 4, half-maximal inhibitory concentration: 15800 nM
Compound 4: the middle estimate sits 1.1-fold (0.04 log units) above what was measured; low and high end bracket the measured number.
By their numbers in this assay, from the lowest: compounds 4, 2, 3 and 1 (each within the scatter of the next).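

Unlike the earlier swaps, which replaced the whole aryl group, this change alters a single substituent para to a large group, and in this assay three heavy atoms and two hydrogen-bond acceptors entering in place of fluoro give only a 1.1-fold lower number from compound 3 to compound 4 (0.05 log units; within the scatter). The wider swaps to the 2-fluoro-4-nitrophenyl group give a 1.1-fold lower number from compound 2 to compound 4 (0.04 log units; within the scatter) and a 1.2-fold lower number from compound 1 to compound 4 (0.08 log units; within the scatter), so all four aryl groups on this oxygen now lie within the scatter of one another. Nothing available explains this flat response.

As far as these compounds go, whether it would hold for an amine or a longer alkyl chain at this place remains open. All four compounds also share the rest of the core of compound 1, so whether this end matters when other parts change is unresolved.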